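The compounds below may be only part of what the source reports. "The series", "measured", "known", "first", "only" and "open" are said of these compounds alone.

Two compounds in this set have a measurement. Compound 1 `Nc1ncnc2c1c(-c1cc(C3CC3)on1)nn2C1CCCCC1` was tested in an assay on TT cells for inhibition of proto-oncogene tyrosine-protein kinase receptor Ret variant C634W (Homo sapiens), read by MTT assay, with a stated time of 10 days (on this read-out lower numbers stand for stronger inhibition of growth and higher numbers for weaker inhibition of growth), where compound 1 gives 290 nM. Compound 2 `CC(C)n1nc(/C=N/OCc2ccccc2)c2c(N)ncnc21` was run in the same test, and compound 2 gives 9270 nM. Compound 1 therefore has the lower of the two numbers, and compound 2 stands far above it, well outside the usual scatter of repeated runs; since the two differ in more than one place, the values alone show only that gap, not what causes it.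

Compound 3 `CC(C)(O)Cn1nc(-c2cc(C3CC3)on2)c2c(N)ncnc21` has not yet been measured. It keeps the core of compound 1 and its 5-cyclopropyl-1,2-oxazol-3-yl group, and differs only at the aromatic nitrogen: 2-hydroxy-2-methylpropyl in place of cyclohexyl on an aromatic nitrogen. A ring of six carbons is exchanged for an open chain that carries a hydroxyl, adding one hydrogen-bond donor and one acceptor where compound 1 had none.

For the measured compounds named here, no single-change step between measured compounds is available to anchor this exchange. The expectation is a modest weakening from compound 1, as the step of a 2.8-fold higher number from compound 1 to compound 3 (0.44 log units; beyond the scatter), which may or may not exceed the scatter. Compound 3 is estimated at 800 nM, with a likely range from 250 nM to 2500 nM.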

Compound 3, concentration for 50% growth inhibition: 4250 nM
Compound 3: middle estimate off by 5.3-fold (0.73 log units), on the low side; measured number outside the range, above it.
By their numbers in this assay, from the lowest: compound 1; then compound 3; then compound 2.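

In this assay, the group on this aromatic nitrogen clearly matters: putting 2-hydroxy-2-methylpropyl in place of cyclohexyl, with the rest of the molecule unchanged, gives a 15-fold higher number from compound 1 to compound 3 (1.17 log units; beyond the scatter) and so weakens growth inhibition by a large margin. For the compounds shown here, this is the first comparison here that changes only one place, so the gap can be tied to this single exchange, which the earlier pair of compounds, differing in more than one place, could not show. No separate measurement is available to explain the change, so the result remains an observation without a demonstrated cause.

The exchange removes a six-membered carbon ring and introduces a hydroxyl in one move, so the compounds shown leave open whether losing the ring, gaining the hydroxyl, or both together accounts for the weaker result. As far as these compounds go, an open chain without the hydroxyl, such as isobutyl, or a cyclohexyl ring bearing a hydroxyl, would help separate these two parts of the change, while the effect of an amine or a carboxylic acid at this position also remains unknown.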